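A few compounds are considered here, and "the series" means these few. Any claim that something is new, unique, unknown or untested is made for them only; others in the source may bear on it.

Two compounds share the core. Compound 1 `CCCC(=O)Nc1cccc(S(=O)(=O)Oc2ccccc2C(C)C)c1` in a functional assay on HT-29 cells (Homo sapiens) for antiproliferative activity, read by sulforhodamine B assay, with a stated time of 48 h (on this read-out higher numbers stand for weaker inhibition and lower numbers for stronger inhibition), gives 13000 nM. Compound 2 `CCCCCC(=O)Nc1ccc(S(=O)(=O)Oc2ccccc2C(C)C)cc1` in this assay gives 6400 nM, the lower of the two numbers; the number of compound 1 lies higher, beyond the scatter. Compound 3 `CCNC(=O)Nc1ccc(S(=O)(=O)Oc2ccccc2C(C)C)cc1` is not yet measured and carries ethylamino in place of pentyl on a carbonyl carbon. For the measured compounds named here, no measured step covers this change; a small move toward a higher number, close to the scatter, is expected. For compound 3 the estimate in this assay is 12000 nM, with a range from 4000 nM to 40000 nM. This estimate means an expected step of a 1.9-fold higher number from compound 2 to compound 3 (0.27 log units; within the scatter).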

Compound 3, half-maximal inhibitory concentration: 1100 nM
Estimate against measurement, compound 3: 11-fold (1.04 log units) above; the measured number lies below the stated range.
By their numbers in this assay, from the lowest: compound 3; then compound 2; then compound 1.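

This position on the carbonyl carbon is sensitive to the group it carries: in this assay, ethylamino in place of pentyl gives a 5.8-fold lower number from compound 2 to compound 3 (0.76 log units; beyond the scatter). The exchange shortens the chain and brings in a nitrogen with a hydrogen-bond donor, so the step reflects both differences together. No available evidence bears on the origin of this step.

The compounds shown leave the contributions of chain length and nitrogen unseparated. Propyl or pentylamino at this carbonyl carbon would bear on that question.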